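A 4-fluorophenyl in place of 3-hydroxyphenyl

A few compounds are considered here, and "the series" means these few. Any claim that something is new, unique, unknown or untested is made for them only; others in the source may bear on it.

Compound 1 `O=S(=O)(c1ccc(Br)cc1)c1nc2ccccc2nc1Nc1ccccc1` gives 1180 nM in a functional assay on PC-3 cells (Homo sapiens) for cytotoxicity, read by MTT assay, with a stated time of 72 h; on this read-out higher numbers stand for weaker inhibition and lower numbers for stronger inhibition.
Compound 2 `Nc1ccc(Nc2nc3ccccc3nc2S(=O)(=O)c2ccc(Br)cc2)cc1` gives 2330 nM in this assay.
Compound 3 `O=S(=O)(c1ccc(Br)cc1)c1nc2ccccc2nc1Nc1cccc(O)c1` gives 1700 nM in this assay.

Among these three numbers compound 3 stands second highest. Its nearest neighbour is compound 2, with the step of a 1.4-fold lower number from compound 2 to compound 3 (0.14 log units; within the scatter); its furthest is compound 1, with the step of a 1.4-fold higher number from compound 1 to compound 3 (0.16 log units; within the scatter). Neither step leaves the scatter, so the three compounds cannot be ordered on these data.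

Compound 4 `O=S(=O)(c1ccc(Br)cc1)c1nc2ccccc2nc1Nc1ccc(F)cc1` has not yet been measured in this assay. It differs from compound 3 in one place: 4-fluorophenyl in place of 3-hydroxyphenyl on a nitrogen on an aromatic ring. Going by the values given here, no measured compound carries fluorine, so there is no step that shows this exact change. What the set does show is that every change made so far at this nitrogen, namely a 2.0-fold higher number from compound 1 to compound 2 (0.30 log units; within the scatter), a 1.4-fold higher number from compound 1 to compound 3 (0.16 log units; within the scatter) and a 1.4-fold lower number from compound 2 to compound 3 (0.14 log units; within the scatter), stayed within the scatter, whether a donor group was added, removed or moved around the ring. On that basis the expected step for compound 4 is also none beyond the scatter, a 1.1-fold lower number from compound 3 to compound 4 (0.05 log units; within the scatter). Compound 4 is therefore estimated at 1500 nM in this assay, with a range from 700 nM to 3500 nM.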

Compound 4, half-maximal inhibitory concentration: 9160 nM
Compound 4: the middle estimate sits 6.1-fold (0.79 log units) below what was measured; measured number above the stated range.
By their numbers in this assay, from the lowest: compounds 1, 3 and 2 (each within the scatter of the next); then compound 4.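

In this assay, going by these compounds alone, the nitrogen on the aromatic ring proves less tolerant than the earlier compounds suggested: 4-fluorophenyl is the first group there to carry the number beyond the scatter, in the step against 3-hydroxyphenyl (a 5.4-fold higher number from compound 3 to compound 4 (0.73 log units; beyond the scatter)) and again in the step against 4-aminophenyl (a 3.9-fold higher number from compound 2 to compound 4 (0.59 log units; beyond the scatter)). Fluoro in place of hydrogen on the plain phenyl ring also leaves the scatter (a 7.8-fold higher number from compound 1 to compound 4 (0.89 log units; beyond the scatter)), whereas amino and hydroxy on that ring did not, so the ring's tolerance depends on which group is added, and compound 4 is the weakest of the four. No evidence is available that bears on this result.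

The compounds shown leave open whether the rise belongs to the fluorine itself or to the place it holds on the ring, a question that a 3-fluorophenyl or a 4-hydroxyphenyl group on this nitrogen would address. They also leave open how a 4-chlorophenyl group, a 4-methoxyphenyl group or a saturated cyclohexyl ring would read at the same nitrogen.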